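A few compounds are considered here, and "the series" means these few. Any claim that something is new, unique, unknown or untested is made for them only; others in the source may bear on it.

Measured compounds in the series:

Compound 1 `O=C(Nc1cccc(-n2cc(-c3ccncc3)c(-c3cc(O)cc(Cl)c3)n2)c1)Nc1ccc(Cl)c(C(F)(F)F)c1` — 97%
Compound 2 `O=C(Nc1cccc(-n2cc(-c3ccncc3)c(-c3cc(O)cc(Cl)c3)n2)c1)Nc1ccc(Cl)c(Cl)c1` — 96%
Compound 3 `COc1cc(Cl)cc(-c2nn(-c3cccc(NC(=O)Nc4ccc(Cl)c(C(F)(F)F)c4)c3)cc2-c2ccncc2)c1` — 98%

All three were tested in a functional assay on SW-620 cells (Homo sapiens) for inhibition, read by sulforhodamine B assay, with a stated time of 48 h, tested at 0.01 uM; on this read-out higher numbers stand for a weaker effect at the one concentration tested and lower numbers for a stronger effect. Compound 3 gives 98% in this assay; it sits at the upper end of the three numbers, but the gap is small: a number 1 percentage points higher from compound 1 to compound 3 (within the scatter), and the two values of compound 2 and compound 3 lie within the scatter of each other as well. On these numbers the three compounds are indistinguishable, and all show only a weak effect at the single concentration tested.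

Compound 4 `COc1cc(Cl)cc(-c2nn(-c3cccc(NC(=O)Nc4ccc(Cl)c(Cl)c4)c3)cc2-c2ccncc2)c1` is the next member. Relative to compound 3 the change is chloro in place of trifluoromethyl on an aromatic carbon, on the ring that carries the chloro group, with the rest of the shared core kept.

The same exchange has already been made once in the series, on the hydroxy congener: a number 1 percentage points lower from compound 1 to compound 2 (within the scatter), within the scatter. Going by the values given here, that is the only measured step that bears on the present one, and it gives no sign of a shift beyond the noise. The step from compound 3 to compound 4 is therefore expected to be a number 1 percentage points lower from compound 3 to compound 4 (within the scatter), with no direction beyond the scatter. Compound 4 is estimated to give 97% in this assay, with a range of 90% to 101%.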

Compound 4, a percentage reported as activity, at one concentration (the size of the read-out at that concentration, not a potency): 100%
Compound 4: the middle estimate sits 3 percentage points below what was measured; measured number inside the range.
By their numbers in this assay, from the lowest: compounds 2, 1, 3 and 4 (each within the scatter of the next).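

The exchange of trifluoromethyl for chloro now has a second reading in this assay, a number 2 percentage points higher from compound 3 to compound 4 (within the scatter), and it reads the same on the core of compound 3 as on the core of compound 1: the same change on two cores in this assay, a number 1 percentage points lower (within the scatter) from compound 1 to compound 2 and a number 2 percentage points higher (within the scatter) from compound 3 to compound 4, 3 percentage points apart, within the scatter of two such steps. Methyl in place of hydrogen on the oxygen also has a second reading, a number 4 percentage points higher from compound 2 to compound 4 (within the scatter), and again the two settings do not separate: the same change on two cores in this assay, a number 1 percentage points higher (within the scatter) from compound 1 to compound 3 and a number 4 percentage points higher (within the scatter) from compound 2 to compound 4, 3 percentage points apart, within the scatter of two such steps. Neither change therefore moves the number beyond the scatter at this single concentration, and all four compounds show only a weak effect.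

Going by these compounds, a single concentration gives no potency, so whether either change matters where the effect is stronger stays open. Also open, on these data alone, is how a nitrile or an amine would read in place of the chloro or trifluoromethyl group.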